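Swapping propyl for an aryl sulfide in an acylguanidine series

The compounds below may be only part of what the source reports. "The series", "measured", "known", "first", "only" and "open" are said of these compounds alone.

Compound 1 `CS(=O)(=O)c1cc(C(=O)N=C(N)N)c(Cl)cc1Cl`: 140 nM
Compound 2 `CCCc1cc(C)c(C(=O)N=C(N)N)cc1S(C)(=O)=O`: 5.7 nM
Compound 3 `Cc1cc(Br)c(C(=O)N=C(N)N)cc1S(C)(=O)=O`: 70 nM

In a functional assay for inhibition of sodium/hydrogen exchanger (Oryctolagus cuniculus) (on this read-out higher numbers stand for weaker inhibition and lower numbers for stronger inhibition), compound 2 gives 5.7 nM, the lowest of the three numbers. Compound 3 gives 70 nM, a gap beyond the scatter, and compound 1 gives 140 nM, further away still. Compound 4 `Cc1cc(Sc2cccc(Cl)c2)c(S(C)(=O)=O)cc1C(=O)N=C(N)N` has not yet been measured. It differs from compound 2 in one place: (3-chlorophenyl)sulfanyl in place of propyl on an aromatic carbon. The entering group sits ortho to a methylsulfonyl group, meta to a methyl group and para to a group of 6 heavy atoms. Going by the values given here, no two measured compounds differ in a single place, so no step can be read from the data. A weaker number is expected for compound 4, with an estimated step of a 3.5-fold higher number from compound 2 to compound 4 (0.55 log units; beyond the scatter). Compound 4 is expected to give 20 nM, within a range from 4 nM to 100 nM.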

Compound 4, half-maximal inhibitory concentration: 37 nM
The estimate for compound 4 lay 1.9-fold (0.27 log units) below the measured number, and the stated range covers the measured number.
By their numbers in this assay, from the lowest: compound 2; then compounds 4, 3 and 1 (each within the scatter of the next, the first and the last beyond it).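

Going by these compounds alone, the change from propyl to (3-chlorophenyl)sulfanyl gives a 6.5-fold higher number from compound 2 to compound 4 (0.81 log units; beyond the scatter) in this assay, the first step in this set that can be read at a single position. Inhibition is weaker with the larger, ring-bearing group, but compound 4 still gives 37 nM, so this position tolerates that group without losing activity. No available evidence accounts for the size of this step.

As far as these compounds go, whether the sulfur, the ring or the chlorine sets the step remains open. So does how phenylsulfanyl, phenoxy or a longer chain such as butyl would read at this position.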